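This account rests on a few compounds, and the source may have more. Where it says the series, first, only, none or still open, it means among the compounds named here.

Compound 1 `NC(=O)c1c(NC(=O)c2ccccc2F)sc2c1CCN(C(=S)Nc1ccccc1Cl)C2` and compound 2 `NC(=O)c1c(NC(=O)c2cccc([N+](=O)[O-])c2)sc2c1CCN(C(=S)Nc1ccccc1Cl)C2` share one core and differ only in the group attached to the carbonyl carbon of the amide. In a functional assay on HL-60 cells (Homo sapiens) for antiproliferative activity, with a stated time of 24 h (a higher number here means a weaker inhibitor, a lower number a stronger inhibitor), compound 1 gives 12500 nM, and in this assay compound 2 gives 7040 nM. The step of a 1.8-fold lower number from compound 1 to compound 2 (0.25 log units; within the scatter) shows that these two values cannot be told apart; compound 2 therefore stands together with compound 1 rather than apart from it. Compound 3 `NC(=O)c1c(NC(=O)c2ccncn2)sc2c1CCN(C(=S)Nc1ccccc1Cl)C2` carries the change (pyrimidin-4-yl in place of 3-nitrophenyl on a carbonyl carbon). Within the data shown here, only one measured step bears on it, the exchange of one aryl group for another at this same carbonyl carbon, which is a 1.8-fold lower number from compound 1 to compound 2 (0.25 log units; within the scatter) and stayed within the scatter. The expected step of a 1.3-fold higher number from compound 2 to compound 3 (0.11 log units; within the scatter) is therefore none beyond the scatter. Compound 3 is estimated at 9000 nM in this assay, with a range from 3000 nM to 30000 nM.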

Compound 3, half-maximal inhibitory concentration: 34600 nM
The estimate for compound 3 lay 3.8-fold (0.58 log units) below the measured number; the measured number lies above the stated range.
By their numbers in this assay, from the lowest: compounds 2 and 1 (each within the scatter of the next); then compound 3.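

At this carbonyl carbon, the aryl group cannot be exchanged freely in this assay: pyrimidin-4-yl gives a 4.9-fold higher number from compound 2 to compound 3 (0.69 log units; beyond the scatter) and, measured against the 2-fluorophenyl compound, a 2.8-fold higher number from compound 1 to compound 3 (0.44 log units; beyond the scatter) as well, so both steps point toward a weaker inhibitor. Among these compounds, the two compounds with a ring of carbon only stay within the scatter of each other, while the one compound whose ring holds hetero atoms stands apart, a contrast that rests on compound 3 alone. Nothing shown here gives a reason for this weakening.

As far as these compounds go, whether the weakening belongs to hetero atoms in the ring generally or to pyrimidin-4-yl in particular stays open. A pyridine ring, with a single ring nitrogen, or a phenyl ring carrying an amine could help separate these two readings.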